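Acetyl to Benzoyl on a Shared Amine Nitrogen

The source may report more compounds than this note shows. Statements on the series, on what has been measured and on what is new or still open speak of the compounds shown alone.

compound 1 `CS(=O)(=O)NC1Cc2ccc(NC(=O)c3ccccc3-c3ccc(C(F)(F)F)cc3)cc2C1` 120 nM
compound 2 `CC(=O)NC1Cc2ccc(NC(=O)c3ccccc3-c3ccc(C(F)(F)F)cc3)cc2C1` 80 nM

In an assay on isolated protein for inhibition of microsomal triglyceride transfer protein large subunit (Homo sapiens) (on this read-out lower numbers stand for stronger inhibition and higher numbers for weaker inhibition), compound 2 gives 80 nM. Within the data shown here, the only measured step, a 1.5-fold lower number from compound 1 to compound 2 (0.18 log units; within the scatter), is within the scatter, so the two compounds stand level; that step put acetyl in place of methylsulfonyl on an amine nitrogen. Compound 3 `O=C(NC1Cc2ccc(NC(=O)c3ccccc3-c3ccc(C(F)(F)F)cc3)cc2C1)c1ccccc1` carries phenyl in place of methyl on a carbonyl carbon, acetyl to benzoyl. Among the measured compounds shown here, that step touches the same amide but at its carbonyl carbon, a change no measured pair covers, and the one step nearby was small. Compound 3 is therefore expected near compound 2, a 1.9-fold higher number from compound 2 to compound 3 (0.27 log units; within the scatter), at an estimated 150 nM, within 40 nM to 600 nM.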

Compound 3, half-maximal inhibitory concentration: > 1000 nM
Compound 3 ended at the assay's limit; the forecaster's own chance of this, stated with the estimate: 5%; at least 6.6-fold (0.82 log units) between middle value and limit.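

In this assay compound 3 gives > 1000 nM, which is a limit and not a number. Phenyl in place of methyl on the carbonyl carbon gives an at least 12-fold higher number from compound 2 to compound 3 (1.09 log units; beyond the scatter), and benzoyl in place of methylsulfonyl on the amine nitrogen gives an at least 8.3-fold higher number from compound 1 to compound 3 (0.92 log units; beyond the scatter). The earlier pair stayed within the scatter and made this amine nitrogen look open to change, but these steps show that it does not accept every group.

On these data alone, with only methyl and phenyl on this carbonyl carbon, it remains open how an ethyl group, a longer chain or a cyclohexyl ring would read. The compounds shown also cannot tell whether the loss belongs to the aromatic ring itself or to the larger count of atoms.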